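From methyl to bromo on the shared core

The source may report more compounds than this note shows. Statements on the series, on what has been measured and on what is new or still open speak of the compounds shown alone.

Measured in an ADME assay on HepG2 cells (Homo sapiens) for cytotoxicity, read by trypan blue exclusion, with a stated time of 48 h, in the presence of a further agent that is not named here; on this read-out higher numbers stand for lower toxicity in this test and lower numbers for higher toxicity in this test:
- Compound 1 `COc1ccccc1NC(=O)COc1cc(C)nc2ccc(C(F)(F)F)cc12`: > 128000 nM (a limit)
- Compound 2 `COc1ccc2nc(C)cc(OCC(=O)Nc3ccc(Br)cc3)c2c1`: > 125000 nM (a limit)
- Compound 3 `COc1ccccc1NC(=O)COc1cc(C)nc2ccc(C)cc12`: > 74000 nM (a limit)

In this assay, compound 3 gives > 74000 nM, which is a limit and not a number. No value shown is an exact number, so compound 3 has no readable rank among the three. Compound 4 `COc1ccccc1NC(=O)COc1cc(C)nc2ccc(Br)cc12` carries bromo in place of methyl on an aromatic carbon. For the measured compounds named here, the one measured step at this carbon is a step that the two limits leave unreadable from compound 1 to compound 3. It gives no size to build on, so no step beyond the scatter and no direction is expected. The expected change is a step that the limit leaves unreadable from compound 3 to compound 4. A further limit is the likeliest result. For compound 4 the estimated value is 100000 nM, with an expected range from 50000 nM to 130000 nM.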

Compound 4, half-maximal cytotoxic concentration: > 125000 nM
Compound 4: only a limit was reported; the forecaster's own chance of this, stated with the estimate: 85%; at least 1.2-fold (0.09 log units) between middle value and limit.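

Compound 4 gives > 125000 nM in this assay, which is a limit and not a number. For the compounds shown here, compound 1, compound 3 and compound 4 all give limits, so no step between them can be read. Going by these compounds, whether methyl, trifluoromethyl and bromo on the shared core differ at all in toxicity in this test stays open.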